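This account rests on a few compounds, and the source may have more. Where it says the series, first, only, none or still open, it means among the compounds named here.

Measured so far in a functional assay on NCI-H460 cells (Homo sapiens) for antiproliferative activity, read by MTT assay, with a stated time of 48 h; on this read-out lower numbers stand for stronger inhibition and higher numbers for weaker inhibition:

Compound 1, `Cc1ccc(Nc2ccc3c(c2)/C(=C\C2CCCCC2)C(=O)N3)cc1`, gives 45500 nM.
Compound 2, `O=C1Nc2ccc(Nc3ccc(Cl)cc3)cc2/C1=C\C1CCCCC1`, gives 13200 nM.
Compound 3, `Cc1ccc(Nc2ccc3c(c2)C(CCC(C)C)C(=O)N3)cc1`, gives 55300 nM.

Compound 1 and compound 2 share one core and differ in a single place: chloro in place of methyl on an aromatic carbon. That change gave a 3.4-fold lower number from compound 1 to compound 2 (0.54 log units; beyond the scatter). Compound 3 is built on a different core, and how the core of compound 3 differs from the core of compound 1 is not broken down here. In this assay compound 3 and compound 1 give numbers that lie within the usual scatter of each other, so nothing separates them.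

Compound 4, `CC(C)CCC1C(=O)Nc2ccc(Nc3ccc(Cl)cc3)cc21`, has not yet been measured. It differs from compound 3 in one place: chloro in place of methyl on an aromatic carbon. The place is described in the same words as for the change from compound 1 to compound 2, so this is the same change, now made on the core of compound 3. Among the compounds with values here, the only guide is the earlier instance, which gave a 3.4-fold lower number from compound 1 to compound 2 (0.54 log units; beyond the scatter), and no measured pair shows whether it carries over to the other core. Taking that step as the guide, compound 4 is expected to show a 3.5-fold lower number from compound 3 to compound 4 (0.54 log units; beyond the scatter) in this assay. Within the data shown here, compound 4 is therefore estimated at 16000 nM, with a range from 7000 nM to 40000 nM, kept wide because only the single step of a 3.4-fold lower number from compound 1 to compound 2 (0.54 log units; beyond the scatter) supports it.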

Compound 4, half-maximal inhibitory concentration: 48700 nM
Estimate against measurement, compound 4: 3.0-fold (0.48 log units) below; measured number outside the range, above it.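

On the core of compound 3, putting chloro in place of methyl, the swap from 4-methylphenyl to 4-chlorophenyl, gives no difference that stands out from the usual scatter in this assay: a 1.1-fold lower number from compound 3 to compound 4 (0.06 log units; within the scatter). Set beside the earlier instance, the same change does not give the same result on the two cores, so the step seen on one core cannot simply be transferred to the other: the same change on two cores in this assay, a 3.4-fold lower number (0.54 log units; beyond the scatter) from compound 1 to compound 2 and a 1.1-fold lower number (0.06 log units; within the scatter) from compound 3 to compound 4, 3.0-fold (0.48 log units) apart, beyond the scatter of two such steps This shows that in these four compounds the outcome of the swap depends on the core it is made on, but it does not show which feature of the two cores matters, and with only two pairs it says nothing about how the swap would behave on any third core.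

From the compounds shown here alone, it remains open whether other groups at the same place on the ring, such as fluoro, trifluoromethyl or methoxy, would follow the core of compound 1 or the core of compound 3. Also open, going by these compounds, is whether an amine or a carboxylic acid at that place would show the two cores differing in the same way, or show no such difference at all.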